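A few compounds are considered here, and "the series" means these few. Any claim that something is new, unique, unknown or untested is made for them only; others in the source may bear on it.

Measured so far in a functional assay on HT-29 cells (Homo sapiens) for cytotoxicity, read by MTT assay, with a stated time of 72 h; on this read-out higher numbers stand for weaker inhibition and lower numbers for stronger inhibition:
- Compound 1 `Cc1ccc(NC(=O)CN2CCN(c3nnc(Cc4ccncc4)c4ccccc34)CC2)c(C)c1`: 1930 nM
- Compound 2 `O=C(CN1CCN(c2nnc(Cc3ccncc3)c3ccccc23)CC1)Nc1ccc(Br)cc1`: 1990 nM
- Compound 3 `Cc1ccc(F)cc1NC(=O)CN1CCN(c2nnc(Cc3ccncc3)c3ccccc23)CC1`: 470 nM

Compound 3 has the lowest number of the three, which makes it the strongest inhibitor here, as its steps to both others lie beyond the scatter. Among the compounds with values here, the next compound, compound 4 `O=C(CN1CCN(c2nnc(Cc3ccncc3)c3ccccc23)CC1)Nc1ccc(F)c(Cl)c1`, keeps the shared core and changes only one group: 3-chloro-4-fluorophenyl in place of 5-fluoro-2-methylphenyl on an amide-type nitrogen. In short, 3-chloro-4-fluorophenyl replaces 5-fluoro-2-methylphenyl on an amide-type nitrogen.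

Within the data shown here, three measured steps bear on this, all of them swaps of the group on that same nitrogen. Two are modest: a 4.1-fold lower number from compound 1 to compound 3 (0.61 log units; beyond the scatter) and a 4.2-fold lower number from compound 2 to compound 3 (0.63 log units; beyond the scatter). The third, a 1.0-fold higher number from compound 1 to compound 2 (0.01 log units; within the scatter), lies within the scatter. So far, then, only the group in compound 3 stands apart, and compound 4 gives that group up. Among the measured compounds shown here, no measurement yet shows what 3-chloro-4-fluorophenyl itself does, so three compounds offer only thin guidance. A modest move back toward weaker inhibition seems the most likely outcome, somewhat smaller than the two modest steps. The expected step is a 2.3-fold higher number from compound 3 to compound 4 (0.37 log units; beyond the scatter). Compound 4 is estimated at 1100 nM, with an expected range from 350 nM to 3500 nM.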

Compound 4, half-maximal inhibitory concentration: 880 nM
For compound 4 the middle estimate is 1.3-fold (0.10 log units) above the measured one; measured number inside the range.
By their numbers in this assay, from the lowest: compounds 3 and 4 (each within the scatter of the next); then compounds 1 and 2 (each within the scatter of the next).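

In this assay, replacing 5-fluoro-2-methylphenyl with 3-chloro-4-fluorophenyl gives a 1.9-fold higher number from compound 3 to compound 4 (0.27 log units; within the scatter), so this position accepts a group with a different set of ring substituents without a change that can be told from the usual scatter. The new group also gives a 2.3-fold lower number from compound 2 to compound 4 (0.35 log units; beyond the scatter) and a 2.2-fold lower number from compound 1 to compound 4 (0.34 log units; beyond the scatter), which means compound 3 no longer stands alone: compound 3 and compound 4 form one pair, compound 1 and compound 2 another, and only the groups in the first pair carry a fluorine. Nothing available here explains this split, and four compounds are too few to tie it to the fluorine.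

Going by these compounds, a plain phenyl and a 4-fluorophenyl on the same nitrogen would put that link to a direct test, and how they compare remains open. Also open, on these data alone, is what happens when the aromatic ring on this nitrogen gives way to a saturated ring such as cyclohexyl, or to a pyridine.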